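A few compounds are considered here, and "the series" means these few. Any claim that something is new, unique, unknown or untested is made for them only; others in the source may bear on it.

Working notes on the series. Of the compounds shown here, two have so far been measured in a functional assay on MKN-45 cells (Homo sapiens) for cytotoxicity, read by MTT assay, with a stated time of 48 h; on this read-out lower numbers stand for stronger inhibition and higher numbers for weaker inhibition. Compound 1 `CCCc1nnc(SCc2ccccc2)n1N1C(=O)c2ccccc2C1=O` gives in this assay no number but only the limit of the assay, > 200000 nM. Compound 2 `C=CCSc1nnc(-c2cc(OC)c(OC)c(OC)c2)n1N1C(=O)c2ccccc2C1=O` likewise gives in this assay only a limit, > 200000 nM. Among the compounds with values here, compound 2 therefore stands at the limit rather than at a number, and the one further value shown sits at the same place: the limit of > 200000 nM in this assay, at which 2 of the 2 values shown sit. Within the data shown here, no step between the measured compounds can be counted, as compound 1 and compound 2 differ in more than one place.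

Compound 3 `COc1cc(-c2nnc(SCC(=O)c3ccccc3C)n2N2C(=O)c3ccccc3C2=O)cc(OC)c1OC` is not yet measured in this assay. Relative to compound 2 the change is (2-methylphenyl)carbonyl in place of vinyl on a saturated chain carbon bound to a sulfur. With both values shown at the limit, the step is expected to be none beyond the scatter, an at least 1.1-fold lower number from compound 2 to compound 3 (0.04 log units; that floor lies within the scatter). Compound 3 is accordingly estimated at about 180000 nM, with a range from 60000 nM to 400000 nM, and a limit rather than a number is the likelier outcome.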

Compound 3, half-maximal inhibitory concentration: > 200000 nM
Compound 3: only a limit was reported (the forecaster's own chance of this, stated with the estimate: 60%); middle value at least 1.1-fold (0.04 log units) away from the limit.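

Compound 2 and compound 3 both stand at a limit, not a number, so no step can be read between them. The compounds shown leave open whether any change on the shared core yields a number rather than a limit in this assay at all, and how far apart these compounds truly lie.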